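Replacing the 4-(methylsulfanyl)phenyl Group of Compound 3

This account rests on a few compounds, and the source may have more. Where it says the series, first, only, none or still open, it means among the compounds named here.

Of the compounds shown here, three have been measured in a functional assay on DU-145 cells (Homo sapiens) for inhibition, read by trypan blue exclusion, with a stated time of 96 h; on this read-out higher numbers stand for weaker inhibition of growth and lower numbers for stronger inhibition of growth. There, compound 1 (`O=C(/C(=C\c1ccc(Cl)cc1Cl)S(=O)(=O)c1ccc(Br)cc1)c1ccc(Cl)cc1`) gives 50000 nM and compound 2 (`O=C(/C(=C\c1ccc(O)cc1)SCc1ccc(Cl)cc1)c1ccc(Br)cc1`) gives 10000 nM. Compound 3 (`CSc1ccc(/C=C(\C(=O)c2ccc(Cl)cc2)S(=O)(=O)Cc2ccc(C)cc2)cc1`) gives 10000 nM, level with compound 2 and sharing with it the lowest of the three numbers, while compound 1 stands above them by more than the scatter.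

Compound 4 (`CCOc1ccc(/C=C(\C(=O)c2ccc(Cl)cc2)S(=O)(=O)Cc2ccc(C)cc2)cc1OC`) has 4-ethoxy-3-methoxyphenyl in place of 4-(methylsulfanyl)phenyl on a double-bonded chain carbon bound to a double-bonded chain carbon. Within the data shown here, no two measured compounds differ in only one place, so the data offer no direct guide to the size of this change. The expectation therefore rests on compound 3 at 10000 nM, and no step beyond the scatter is expected in this assay. The expected change is no change at the digits printed from compound 3 to compound 4 (within the scatter). The estimate for compound 4 is 10000 nM, with an expected range from 3000 nM to 40000 nM.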

Compound 4, concentration for 50% growth inhibition: 10000 nM
Beside the measured number, compound 4's estimate shows no gap at the digits printed; the measured number falls inside the stated range.
By their numbers in this assay, from the lowest: compounds 2, 3 and 4 (each within the scatter of the next); then compound 1.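

In this assay, among these compounds, putting 4-ethoxy-3-methoxyphenyl in place of 4-(methylsulfanyl)phenyl on a double-bonded chain carbon bound to a double-bonded chain carbon gives no change at the digits printed from compound 3 to compound 4 (within the scatter), the first step that can be read between two compounds differing in one place. At this position, then, a group of 11 heavy atoms with two oxygens and a group of 8 heavy atoms with one sulfur stand level, even though the entering group carries two hydrogen-bond acceptors where the leaving group carries one. Nothing available bears on why the two compounds stand level.

As far as these compounds go, whether an amine, a carboxylic acid or a longer alkoxy chain at this position would also stand level remains open. So does whether any group here can give a number clearly lower than that of compound 3.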